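The source may report more compounds than this note shows. Statements on the series, on what has been measured and on what is new or still open speak of the compounds shown alone.

Measured so far in a functional assay on HeLa cells (Homo sapiens) for inhibition, read by MTT assay, with a stated time of 48 h; on this read-out lower numbers stand for stronger inhibition and higher numbers for weaker inhibition:

Compound 1, `COc1ccc2c(=O)c(/C=C/C(=O)NCc3ccc(C)cc3)coc2c1`, gives only a limit in this assay, > 100000 nM.
Compound 2, `Cc1ccccc1NC(=O)/C=C/c1coc2cc(O)ccc2c1=O`, gives 8670 nM in this assay.
Compound 3, `COc1ccc2c(=O)c(/C=C/C(=O)Nc3ccccc3C)coc2c1`, gives 7270 nM in this assay.

Compound 2 and compound 3 share one core and differ only in hydrogen in place of methyl on an oxygen on an aromatic ring; this step reads a 1.2-fold lower number from compound 2 to compound 3 (0.08 log units; within the scatter), so the two are not told apart here. Compound 3 and compound 1 differ in 4-methylbenzyl in place of 2-methylphenyl on an amide-type nitrogen, and that step reads an at least 13-fold higher number from compound 3 to compound 1 (1.13 log units; beyond the scatter), with compound 1 sitting at the limit of > 100000 nM in this assay, at which 1 of the 3 values shown sits. Among the compounds shown this change occurs twice in all: from compound 3 to compound 1, measured, and from compound 2 to compound 4, not yet measured.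

Compound 4, `Cc1ccc(CNC(=O)/C=C/c2coc3cc(O)ccc3c2=O)cc1`, stands to compound 2 as compound 1 stands to compound 3: the difference is 4-methylbenzyl in place of 2-methylphenyl on an amide-type nitrogen, the same place in both pairs. The core of compound 4 is that of compound 2, differing from the core of compound 3 by hydrogen in place of methyl on an oxygen on an aromatic ring, a change that moved nothing beyond the scatter.

For compound 4 a step of about a 12-fold higher number from compound 2 to compound 4 (1.06 log units; beyond the scatter) is therefore expected in this assay, of a size like the measured one from compound 3 to compound 1, an at least 13-fold higher number from compound 3 to compound 1 (1.13 log units; beyond the scatter), resting on that single pair and on the near-identity of compound 2 and compound 3. Compound 4 is estimated at 100000 nM, with a likely range of 30000 nM to 300000 nM, and a fair chance that this assay again reports only a limit for it.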

Compound 4, half-maximal inhibitory concentration: > 100000 nM
Compound 4: a limit, no number; the forecaster's own chance of this, stated with the estimate: 60%; the middle value sits exactly at the limit.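

In this assay, 4-methylbenzyl in place of 2-methylphenyl on the amide-type nitrogen gives an at least 11-fold higher number from compound 2 to compound 4 (1.06 log units; beyond the scatter), so the large step seen on the core of compound 3 also appears on the core of compound 2. The change therefore carries across these two cores in direction and in being beyond the scatter, although how closely the two sizes match stays unsettled: the same change on two cores in this assay, an at least 13-fold higher number (1.13 log units; beyond the scatter) from compound 3 to compound 1 and an at least 11-fold higher number (1.06 log units; beyond the scatter) from compound 2 to compound 4; the limit leaves it open whether they differ Both 4-methylbenzyl compounds end at a limit rather than a number, so neither step has a known full size and the step between compound 1 and compound 4 cannot be read: the limit of > 100000 nM in this assay, at which 2 of the 4 values shown sit.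

The compounds shown leave open which part of the change goes with the step, since the two groups differ both in the methyl position printed in their names and in the benzyl form, and neither 4-methylphenyl nor 2-methylbenzyl appears here to separate the two. Also open, as far as these compounds go, is how far the amide-type nitrogen tolerates other groups on either core, such as an unsubstituted benzyl, a longer phenylethyl chain, or a phenyl ring carrying an amine or a carboxylic acid.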